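A few compounds are considered here, and "the series" means these few. Any claim that something is new, unique, unknown or untested is made for them only; others in the source may bear on it.

Measured in a functional assay on MCF7 cells (Homo sapiens) for antiproliferative activity, read by MTT assay, with a stated time of 72 h; on this read-out higher numbers stand for weaker inhibition and lower numbers for stronger inhibition:
- compound 1 `C=CC(=O)Nc1cccc(Oc2nc(Nc3ccn(C)n3)nc3c2CSCC3)c1`: > 50000 nM, a limit
- compound 2 `CCC/C=C/C(=O)Nc1cccc(Oc2nc(Nc3ccn(C)n3)nc3c2CSCC3)c1`: 22600 nM
- compound 3 `C=C(C)C(=O)Nc1cccc(Oc2nc(Nc3ccn(C)n3)nc3c2CSCC3)c1`: > 50000 nM, a limit

Compound 1 has no numerical value, only the limit > 50000 nM. It shares that position with one other compound: the limit of > 50000 nM in this assay, at which 2 of the 3 values shown sit.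

Compound 4 `C=CC(=O)Nc1cccc(Oc2nc(Nc3cccc(OC)c3)nc3c2CSCC3)c1` has not yet been measured. It keeps the core and the acrylamide end of compound 1 but changes the group on the amino nitrogen: 3-methoxyphenyl in place of 1-methyl-1H-pyrazol-3-yl on a nitrogen on an aromatic ring. In words, 3-methoxyphenyl stands in place of 1-methyl-1H-pyrazol-3-yl on a nitrogen on an aromatic ring.

Going by the values given here, no measured step touches this place, since all three change the group on the carbonyl carbon. They are an at least 2.2-fold lower number from compound 1 to compound 2 (0.34 log units; beyond the scatter), an at least 2.2-fold higher number from compound 2 to compound 3 (0.34 log units; beyond the scatter) and a step that the two limits leave unreadable from compound 1 to compound 3. They therefore show only how far this series has moved with changes at that other place. Of the three compounds, compound 2 alone has a numerical value, 22600 nM. On that basis, a modest step towards a lower number is expected in this assay, with a real chance that compound 4 also stays at the limit. The expected change is an at least 2.2-fold lower number from compound 1 to compound 4 (0.35 log units; beyond the scatter). For compound 4 the estimated value is 22000 nM, with an expected range from 6000 nM to 60000 nM.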

Compound 4, half-maximal inhibitory concentration: > 50000 nM
Compound 4 ended at the assay's limit; the forecaster's own chance of this, stated with the estimate: 40%; middle value at least 2.2-fold (0.35 log units) from the limit.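

In this assay compound 4 gives > 50000 nM, which is a limit. Compound 1 also stands at a limit, so the step between compound 1 and compound 4 cannot be read: the limit of > 50000 nM in this assay, at which 3 of the 4 values shown sit.

The compounds shown leave open whether 3-methoxyphenyl in place of 1-methyl-1H-pyrazol-3-yl on a nitrogen on an aromatic ring changes the antiproliferative read-out at all.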